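Swapping a methoxypyridyl amide for a phenethyl amide

This account rests on a few compounds, and the source may have more. Where it says the series, first, only, none or still open, it means among the compounds named here.

Within the data shown here, compound 1 `COc1cccc(C(=O)Nc2cnn(Cc3c(C)noc3C)c2)n1` gives 700 nM in a functional assay on cells for antagonist activity at taste receptor type 2 member 8 (Homo sapiens), read by FLIPR and calcium flux, with a stated time of 100 s (a lower number here means a stronger inhibitor, a higher number a weaker inhibitor), and stands lowest of the two numbers measured so far; compound 2 `Cc1noc(C)c1Cn1cc(N2Cc3ccccc3C2=O)cn1` gives 9000 nM in this assay, a gap beyond the usual scatter. Compound 3 `Cc1noc(C)c1Cn1cc(NC(=O)CCc2ccccc2)cn1` has not yet been measured; it differs from compound 1 in one place (phenethyl in place of 6-methoxypyridin-2-yl on a carbonyl carbon). Among the measured compounds shown here, no step between measured compounds is available for this change; a modest weakening of inhibition is expected, a step of a 2.1-fold higher number from compound 1 to compound 3 (0.33 log units; beyond the scatter) that goes somewhat beyond the scatter. Compound 3 is therefore estimated at 1500 nM, with a range from 500 nM to 5000 nM.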

Compound 3, half-maximal inhibitory concentration: 400 nM
Estimate against measurement, compound 3: 3.8-fold (0.57 log units) above; measured number below the stated range.
By their numbers in this assay, from the lowest: compounds 3 and 1 (each within the scatter of the next); then compound 2.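

In this assay, phenethyl in place of 6-methoxypyridin-2-yl on a carbonyl carbon gives a 1.8-fold lower number from compound 1 to compound 3 (0.24 log units; within the scatter) and so leaves the two compounds level. At this position, then, a group of carbon only serves as well as the methoxypyridyl group, and neither the ring nitrogen nor the methoxy group is needed to keep this level of inhibition. Nothing measured here explains this result.

As far as these compounds go, whether a benzyl group or a longer chain would do as well remains open. So does the effect of an amine or a carboxylic acid on the phenethyl group.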